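The source may report more compounds than this note shows. Statements on the series, on what has been measured and on what is new or still open speak of the compounds shown alone.

Measured compounds:
- compound 1 `O=C1O[C@H]([C@@H](O)Cn2cc(-c3cc(F)cc(F)c3)nn2)C(OCc2ccccc2)=C1OCc1ccccc1`: in a functional assay on A549 cells (Homo sapiens) for antiproliferative activity, read by MTT assay, with a stated time of 72 h (on this read-out higher numbers stand for weaker inhibition and lower numbers for stronger inhibition), compound 1 gives 41200 nM
- compound 2 `O=C1O[C@H]([C@@H](O)Cn2cc(-c3cc(C(F)(F)F)cc(C(F)(F)F)c3)nn2)C(OCc2ccccc2)=C1OCc1ccccc1`: in this assay compound 2 gives 28900 nM
- compound 3 `CC(C)(C)OC(=O)N1CCN(C(=S)SCc2cn(C[C@H](O)[C@H]3OC(=O)C(OCc4ccccc4)=C3OCc3ccccc3)nn2)CC1`: in this assay compound 3 gives only a limit, > 100000 nM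

Compound 1 holds the highest of the two numbers actually obtained in this assay, though compound 2 lies close to it, within the usual scatter, so no order between the two can be claimed. Compound 3 sits at the limit of the assay, as recorded in the limit of > 100000 nM in this assay, at which 1 of the 3 values shown sits, and so contributes no number to compare against.

Compound 4 `CCCCCc1ccc(-c2cn(C[C@H](O)[C@H]3OC(=O)C(OCc4ccccc4)=C3OCc3ccccc3)nn2)cc1` differs from compound 1 in one place: 4-pentylphenyl in place of 3,5-difluorophenyl on an aromatic carbon

No measured pair among these compounds shows such a step, so there is no direct precedent to lean on. The bis(trifluoromethyl) analogue compound 2 shows that a change of the substituents on this aryl ring moved the number only within the scatter. A modest step toward stronger inhibition is expected, a 2.7-fold lower number from compound 1 to compound 4 (0.44 log units; beyond the scatter), with the real possibility of no step beyond the scatter at all. Compound 4 is therefore estimated at 15000 nM, with a range from 4000 nM to 60000 nM.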

Compound 4, half-maximal inhibitory concentration: 6220 nM
For compound 4 the middle estimate is 2.4-fold (0.38 log units) above the measured one, within the range that was stated.
By their numbers in this assay, from the lowest: compound 4; then compounds 2 and 1 (each within the scatter of the next). At a limit, above all of these: compound 3.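

In this assay the group on an aromatic carbon of the five-membered aromatic ring with 3 nitrogen now has a measured step, with a 6.6-fold lower number from compound 1 to compound 4 (0.82 log units; beyond the scatter) when 4-pentylphenyl replaces 3,5-difluorophenyl. For the compounds shown here, the earlier compounds held no such pair, so this is the first sign that the group carried at this place can move the number beyond the scatter, although the step is modest. The change removes both fluorines and adds a carbon chain in one move, and nothing shown gives a reason for the step.

A plain phenyl, or a butyl or octyl chain in place of the pentyl chain, would be needed to tie the step to the chain itself. The compounds shown also leave open how an amine or a carboxylic acid would read in this assay at this place.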